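This account rests on a few compounds, and the source may have more. Where it says the series, first, only, none or still open, it means among the compounds named here.

Working notes on the series. The shared core is illustrated by compound 1 `O=c1c(SC(=S)N2CCCC2)coc2ccc(Cl)cc12` and compound 2 `O=c1c(SC(=S)N2CCCCC2)coc2ccccc12`, which differ in two places, so only their two values are set side by side here. In a functional assay on MDA-MB-435S cells (Homo sapiens) for antiproliferative activity, read by MTT assay, with a stated time of 72 h (on this read-out lower numbers stand for stronger inhibition and higher numbers for weaker inhibition), compound 1 gives 24000 nM. In this assay compound 2 gives 17400 nM, the lowest of the two numbers available, with compound 1 as its nearest neighbour at a gap that lies within the usual scatter.

Compound 3 `O=c1c(SC(=S)N2CCCCC2)coc2ccc(Cl)cc12` is not yet measured. It differs from compound 2 by chloro in place of hydrogen on an aromatic carbon. Going by the values given here, no single-change step between measured compounds is available to anchor this change. Among the compounds with values here, from compound 2 to compound 3 the expected step in this assay is none beyond the scatter, since the only comparison at hand, compound 1 at 24000 nM against compound 2 at 17400 nM, shows a gap within the scatter. Compound 3 is therefore estimated at 20000 nM, with a range from 9000 nM to 45000 nM, which corresponds to an expected step of a 1.1-fold higher number from compound 2 to compound 3 (0.06 log units; within the scatter).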

Compound 3, half-maximal inhibitory concentration: 13300 nM
Compound 3: the middle estimate sits 1.5-fold (0.18 log units) above what was measured; the range from low to high includes it.
By their numbers in this assay, from the lowest: compounds 3, 2 and 1 (each within the scatter of the next).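

In this assay, going by these compounds alone, chloro in place of hydrogen on an aromatic carbon gives a 1.3-fold lower number from compound 2 to compound 3 (0.12 log units; within the scatter) with the piperidin-1-yl group held fixed, the first single-change reading at this position, and the chloro group is tolerated there without a shift beyond the scatter. With the chloro group held fixed, piperidin-1-yl in place of pyrrolidin-1-yl on a thiocarbonyl carbon gives a 1.8-fold lower number from compound 1 to compound 3 (0.26 log units; within the scatter) and also stays inside the scatter, so neither single change separates these compounds. No accompanying measurement speaks to the origin of either small step.

From the compounds shown here alone, whether a methoxy group or a carboxylic acid on the same aromatic carbon would move the number beyond the scatter remains open. Also open, going by these compounds, is whether a morpholin-4-yl group on the thiocarbonyl carbon would do so.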